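Adding a Methyl to the Amide-Type Nitrogen of Compound 1

The source may report more compounds than this note shows. Statements on the series, on what has been measured and on what is new or still open speak of the compounds shown alone.

Measured in a physicochemical assay for solubility, in phosphate buffer, measured as thermodynamic solubility, at pH 7.4; on this read-out higher numbers stand for higher solubility and lower numbers for lower solubility:
Compound 1 `CS(=O)(=O)NC(=O)CCc1cn(-c2ccc(Br)cc2)nc1-c1ccc(Cl)cc1` gives 170000 nM
Compound 2 `CS(=O)(=O)NC(=O)CCc1cn(-c2ccc(Cl)cc2)nc1-c1ccc(Cl)cc1` gives 100000 nM
Compound 3 `CS(=O)(=O)NC(=O)CCc1cn(-c2ccc(Br)cc2)nc1C1CCNCC1` gives 196000 nM

Compound 1 stands level with both of the others, since neither measured step leaves the scatter: a 1.7-fold lower number from compound 1 to compound 2 (0.23 log units; within the scatter), and a 1.2-fold higher number from compound 1 to compound 3 (0.06 log units; within the scatter). The first step is chloro in place of bromo, and the second is piperidin-4-yl in place of 4-chlorophenyl. Both are changes on an aromatic carbon, and neither leaves a mark on the numbers.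

Compound 4 `CN(C(=O)CCc1cn(-c2ccc(Br)cc2)nc1-c1ccc(Cl)cc1)S(C)(=O)=O` is changed somewhere else. The difference from compound 1 is methyl in place of hydrogen on an amide-type nitrogen, which is methyl in place of hydrogen on an amide-type nitrogen whose other neighbours are the carbonyl carbon and the sulfonyl sulfur. Within the data shown here, no measured compound here carries a change at that nitrogen, so the two flat steps say little about this one. They cannot be carried over, and the expectation rests on the structural change alone, which removes the amide hydrogen. A clearly lower number in this assay is expected, but with wide uncertainty. The expected size is a 34-fold lower number from compound 1 to compound 4 (1.53 log units; beyond the scatter). For compound 4 the estimate is 5000 nM, with an expected range from 500 nM to 40000 nM.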

Compound 4, solubility: < 5000 nM
Compound 4 gave a limit, no number (the forecaster's own chance of this, stated with the estimate: 15%); the middle value lies on the limit itself.
By their numbers in this assay, from the lowest: compounds 2, 1 and 3 (each within the scatter of the next). At a limit, below all of these: compound 4.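

In this assay, among these compounds, methyl in place of hydrogen on the amide-type nitrogen whose other neighbours are the carbonyl carbon and the sulfonyl sulfur gives an at least 34-fold lower number from compound 1 to compound 4 (1.53 log units; beyond the scatter), and this is the first step in the set to go beyond the scatter. The two earlier changes, both on an aromatic carbon, gave a 1.7-fold lower number from compound 1 to compound 2 (0.23 log units; within the scatter) and a 1.2-fold higher number from compound 1 to compound 3 (0.06 log units; within the scatter), so this nitrogen is the one place shown where a single small change clearly moves the read-out, even though only one heavy atom enters. The result for compound 4 is a limit and not a number: the limit of < 5000 nM in this assay, at which 1 of the 4 values shown sits.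

The compounds shown leave open whether the step follows from the loss of the amide hydrogen or from the methyl itself, a question that an ethyl or a longer chain on the same nitrogen, or a carboxylic acid in place of the whole (methylsulfonyl)carbamoyl group, could help to separate. They also leave open whether the same methyl would carry the same step on compound 3, where piperidin-4-yl stands in place of 4-chlorophenyl.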